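A few compounds are considered here, and "the series" means these few. Any claim that something is new, unique, unknown or untested is made for them only; others in the source may bear on it.

Compound 1 `CCCCNc1ccnc2cc(Cl)ccc12` gives 15900 nM in a functional assay on MDA-MB-231 cells (Homo sapiens) for cytotoxicity, read by sulforhodamine B assay, with a stated time of 48 h; a higher number here means a weaker inhibitor of growth, a lower number a stronger inhibitor of growth. Compound 2 `CN(C)CCNc1ccnc2cc(Cl)ccc12` gives 8590 nM in this assay, and compound 3 `CN(C)CCNc1ccnc2cc(F)ccc12` gives 7080 nM. Compound 2 thus stands second highest of the three numbers: its nearest neighbour is compound 3, reached by a 1.2-fold lower number from compound 2 to compound 3 (0.08 log units; within the scatter), and its furthest is compound 1, from which it is reached by a 1.9-fold lower number from compound 1 to compound 2 (0.27 log units; within the scatter). Both steps fall within the scatter, so the three compounds are not separated in this assay.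

The next compound, compound 4 `COc1ccc2c(NCCN(C)C)ccnc2c1`, differs from compound 2 in one place: methoxy in place of chloro on an aromatic carbon. Among the compounds with values here, of the measured steps, the one that also exchanges the group on that aromatic carbon was a 1.2-fold lower number from compound 2 to compound 3 (0.08 log units; within the scatter), within the scatter. Within the data shown here, no measured compound carries a methoxy, so the expectation rests on that halogen exchange alone. For compound 4 the expected step is a 1.1-fold lower number from compound 2 to compound 4 (0.06 log units; within the scatter), none beyond the scatter. Compound 4 is therefore estimated at 7500 nM in this assay, with a range from 3000 nM to 19000 nM.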

Compound 4, concentration for 50% growth inhibition: 4500 nM
Compound 4: middle estimate off by 1.7-fold (0.22 log units), on the high side; the measured number falls inside the stated range.
By their numbers in this assay, from the lowest: compounds 4, 3, 2 and 1 (each within the scatter of the next, the first and the last beyond it).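

In this assay, replacing either halogen on this aromatic carbon with methoxy gives a 1.9-fold lower number from compound 2 to compound 4 (0.28 log units; within the scatter) and a 1.6-fold lower number from compound 3 to compound 4 (0.20 log units; within the scatter), so a group that is not a halogen also stays within the scatter of both. Methoxy brings 2 heavy atoms and 1 hydrogen-bond acceptor where chloro has 1 heavy atom and no acceptor, and this change in the group produces no step beyond the scatter, something the exchange of one halogen for another could not show. Nothing available here explains these values.

Going by these compounds, it remains open whether any group on this carbon would move the number beyond the scatter, for example an amine, a carboxylic acid or a longer alkoxy chain. On these data alone, with methoxy in place, the effect of exchanging the dimethylamino group also remains open.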